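A few compounds are considered here, and "the series" means these few. Any claim that something is new, unique, unknown or untested is made for them only; others in the source may bear on it.

In an ADME assay on cells (Fibroblast, Homo sapiens) for cytotoxicity, read by MTT assay, with a stated time of 24 h (on this read-out higher numbers stand for weaker inhibition and lower numbers for stronger inhibition), compound 1 (`COc1ccc(N(CC(=O)NCCC[Te]c2ccccc2)C(=O)CNC(=O)OC(C)(C)C)cc1`) gives a true reading of 25000 nM. Compound 2 (`COc1ccc(N(CC(=O)NCCC[Se]c2ccccc2)C(=O)c2ccccc2)cc1`) gives only >= 100000 nM, which is a limit of the assay and not a number. Its real position is therefore unknown, and it stands at the limit of >= 100000 nM in this assay, at which 1 of the 2 values shown sits.

Compound 3 (`COc1ccc(N(CC(=O)NCCC[Se]c2ccccc2)C(=O)CNC(=O)OC(C)(C)C)cc1`) is built from compound 2 by a single change, with ((tert-butoxycarbonyl)amino)methyl in place of phenyl on a carbonyl carbon. Among the compounds with values here, no measured pair in this small set shows that change on its own, so any forecast is loose. Within the data shown here, the only true number, compound 1 at 25000 nM, shows that exact readings do occur in this assay. A small move toward stronger inhibition is expected, roughly the size of the usual scatter, with an at least 1.6-fold lower number from compound 2 to compound 3 (0.22 log units; that floor lies within the scatter) as the estimated step. For compound 3 the estimated value is 60000 nM, within an expected range of 20000 nM to 150000 nM.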

Compound 3, half-maximal inhibitory concentration: >= 100000 nM
Compound 3: a limit, no number; the forecaster's own chance of this, stated with the estimate: 45%; middle value at least 1.6-fold (0.22 log units) from the limit.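

In this assay, selenium in place of tellurium, with the rest of the molecule unchanged, gives an at least 4.0-fold higher number from compound 1 to compound 3 (0.60 log units; beyond the scatter). Within the data shown here, this is the first readable comparison in the set, and it shows that the atom on the saturated chain can shift the reading by more than the usual scatter. Compound 2 and compound 3 each stand at a limit of the assay and not at a number, so the step between them, with ((tert-butoxycarbonyl)amino)methyl in place of phenyl on a carbonyl carbon, cannot be read: the limit of >= 100000 nM in this assay, at which 2 of the 3 values shown sit.

As far as these compounds go, how far above that limit either selenium compound truly lies remains unknown, as does whether the carbonyl change would matter where a true reading is possible, as with the tellurium compound. Also open, from the compounds shown here alone, is what a sulfur atom in place of selenium, or a free amine in place of the tert-butoxycarbonyl-protected one, would do to the reading.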